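Swapping a chloropropyl tail for a cyclohexenyl ring

This account rests on a few compounds, and the source may have more. Where it says the series, first, only, none or still open, it means among the compounds named here.

Measured so far in an ADME assay on Huh-5-2 cells (Homo sapiens) for cytotoxicity; a lower number here means that less compound is tolerated, a higher number that more compound is tolerated:
Compound 1, `NC(=O)c1nc(C#CC2(O)CCCCC2)n(COCCO)n1`, gives > 50 ug/mL.
Compound 2, `NC(=O)c1nc(C#CCCCCl)n(COCCO)n1`, gives > 50 ug/mL.

Both of these values are limits of this assay, not numbers. Compound 1 was tolerated up to the top of the tested range. Compound 2 stands at the same place, with only a limit and no number. Going by the values given here, the one measured step, a step that the two limits leave unreadable from compound 1 to compound 2, therefore cannot be sized, because of the limit of > 50 ug/mL in this assay, at which 2 of the 2 values shown sit.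

Compound 3, `NC(=O)c1nc(C#CC2=CCCCC2)n(COCCO)n1`, is the compound to be measured next. It differs from compound 2 in one place: cyclohex-1-en-1-yl in place of 3-chloropropyl on a triple-bonded carbon.

Among the compounds with values here, no measured step gives a readable size, and both measured compounds sit at the limit, so there is no evidence pointing toward a change in either direction. The step expected is a step that the limit leaves unreadable from compound 2 to compound 3, nothing beyond the scatter. Compound 3 is therefore estimated to give 60 ug/mL, in the range 30 ug/mL to 150 ug/mL, most likely reported again as a limit.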

Compound 3, half-maximal cytotoxic concentration: > 50 ug/mL
Compound 3 was reported as a limit; the forecaster's own chance of this, stated with the estimate: 75%; the middle value is on the limit's open side.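

Compound 3 also gives only a limit, so no step among compound 1, compound 2 and compound 3 can be read in this assay, because all three stand at the same place: the limit of > 50 ug/mL in this assay, at which 3 of the 3 values shown sit.

The compounds shown leave open what concentration of any of the three harms these cells, and whether the group on the triple-bonded carbon changes it.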